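The compounds below may be only part of what the source reports. "The series", "measured", "known", "first", "only" and "open" are said of these compounds alone.

Compound 1 `COC(=O)c1cc(F)ccc1OC(=O)COc1cc(O)c2c(=O)cc(-c3ccccc3)oc2c1`, compound 2 `COC(=O)c1c(F)cccc1OC(=O)COc1cc(O)c2c(=O)cc(-c3ccccc3)oc2c1` and compound 3 `COC(=O)c1ccc(C)cc1OC(=O)COc1cc(O)c2c(=O)cc(-c3ccccc3)oc2c1` share one core. In a functional assay on cells (T-cell, Mus musculus, strain BALB/c) for inhibition, read by MTT assay, with a stated time of 72 h (on this read-out higher numbers stand for weaker inhibition and lower numbers for stronger inhibition), compound 1 gives 6820 nM, compound 2 gives 40300 nM and compound 3 gives 31100 nM. Compound 3 thus stands second highest of the three numbers: its nearest neighbour is compound 2, separated by a 1.3-fold lower number from compound 2 to compound 3 (0.11 log units; within the scatter), while compound 1 lies furthest, as shown by a 4.6-fold higher number from compound 1 to compound 3 (0.66 log units; beyond the scatter). Compound 4 `COC(=O)c1cc(O)ccc1OC(=O)COc1cc(O)c2c(=O)cc(-c3ccccc3)oc2c1` is not yet measured and differs from compound 3 in one place: a group of 11 heavy atoms (8 carbon, 3 oxygen; one six-membered aromatic ring of carbon only) in place of a group of 11 heavy atoms (9 carbon, 2 oxygen; one six-membered aromatic ring of carbon only), on an oxygen next to a carbonyl group. Among the compounds with values here, the steps that bear on this change are a 4.6-fold higher number from compound 1 to compound 3 (0.66 log units; beyond the scatter) and a 1.3-fold lower number from compound 2 to compound 3 (0.11 log units; within the scatter), one modest and one within the scatter. Since neither introduces a hydroxyl, compound 4 is expected to move by a 1.6-fold lower number from compound 3 to compound 4 (0.19 log units; within the scatter) in this assay, a step of modest size at most and of uncertain direction. The estimate for compound 4 is 20000 nM, ranging from 6000 nM to 60000 nM.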

Compound 4, half-maximal inhibitory concentration: 29500 nM
The estimate for compound 4 lay 1.5-fold (0.17 log units) below the measured number; measured number inside the range.
By their numbers in this assay, from the lowest: compound 1; then compounds 4, 3 and 2 (each within the scatter of the next).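

In this assay, hydroxy in place of fluoro on an aromatic carbon weakens inhibition (a 4.3-fold higher number from compound 1 to compound 4 (0.64 log units; beyond the scatter)), so the hydroxy group does not reproduce the number of compound 1. The hydroxy-bearing group of compound 4 nevertheless stays within the scatter of the groups it replaces in the other two compounds (a 1.1-fold lower number from compound 3 to compound 4 (0.02 log units; within the scatter)) and (a 1.4-fold lower number from compound 2 to compound 4 (0.14 log units; within the scatter)). Of the four compounds, only compound 1 stands apart.

Nothing available explains these numbers. From the compounds shown here alone, whether an amine or a methoxy group at the hydroxy position would match compound 1 or compound 4 remains open.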